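The source may hold more compounds than are shown below. What is called first, only, known or untested is meant among the compounds shown, and "the series" means these compounds.

Working notes on the series

Compound 1 `CC(C)c1onc(-c2c(Cl)cccc2Cl)c1COc1ccc(-c2nc3ccc(C(=O)O)cc3n2C2CCC2)cc1` and compound 2 `CC(C)c1onc(-c2c(Cl)cccc2Cl)c1COc1ccc(-c2nc3ccc(C(=O)O)cc3n2C2CCCC2)cc1` share one core and differ only in the group on the aromatic nitrogen. In an assay on HEK-293T cells for antagonist activity at vitamin D3 receptor (Homo sapiens), read by a luciferase reporter, with a stated time of 24 h (on this read-out lower numbers stand for stronger inhibition and higher numbers for weaker inhibition), compound 1 gives 1100 nM, and in this assay compound 2 gives 929 nM. Going by the values given here, the only measured step is a 1.2-fold lower number from compound 1 to compound 2 (0.07 log units; within the scatter), so the two numbers are not separated by more than the scatter. On the numbers shown, compound 2 stands beside compound 1 as one of two near-identical readings, with no ranking possible between them.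

Compound 3 `CCCn1c(-c2ccc(OCc3c(-c4c(Cl)cccc4Cl)noc3C(C)C)cc2)nc2ccc(C(=O)O)cc21` carries the change (propyl in place of cyclopentyl on an aromatic nitrogen). Among the compounds with values here, the one step that bears on it is the earlier exchange at the same aromatic nitrogen, a 1.2-fold lower number from compound 1 to compound 2 (0.07 log units; within the scatter), which stayed within the scatter; a second change of the same kind at the same place gives no ground to expect a step beyond the scatter in this assay, in either direction. The estimated step is therefore a 1.1-fold higher number from compound 2 to compound 3 (0.03 log units; within the scatter), flat within the scatter. For compound 3 the expected value in this assay is 1000 nM, with a range from 400 nM to 2500 nM.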

Compound 3, half-maximal inhibitory concentration: 1400 nM
For compound 3 the middle estimate is 1.4-fold (0.15 log units) below the measured one; the measured number falls inside the stated range.
By their numbers in this assay, from the lowest: compounds 2, 1 and 3 (each within the scatter of the next).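

At the aromatic nitrogen, the first open chain in the series reads no differently from the two rings: in this assay, the propyl group gives a 1.5-fold higher number from compound 2 to compound 3 (0.18 log units; within the scatter) against cyclopentyl and a 1.3-fold higher number from compound 1 to compound 3 (0.10 log units; within the scatter) against cyclobutyl. Going by these compounds alone, the earlier pair compared only one ring with another, whereas compound 3 shows that, across these three compounds, a carbon ring on this nitrogen is not needed to keep the number in the same band, and that cyclobutyl, cyclopentyl and propyl cannot be told apart on this read-out. Nothing available gives a reason for this flat result.

From the compounds shown here alone, all three groups at this position contain carbon only, so it remains open whether an amine, a hydroxyl-bearing chain, a phenyl ring or a longer chain such as hexyl on the same nitrogen would move the number beyond the scatter. Going by these compounds, it also remains open whether this flat behaviour would hold if the shared core changed elsewhere, for example with an amide in place of the carboxylic acid.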